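Pyrazole Substituent Changes on a Shared Core

The source may report more compounds than this note shows. Statements on the series, on what has been measured and on what is new or still open speak of the compounds shown alone.

Of the compounds shown here, three sharing one core have been measured in an assay on cells for inhibition of thyroid peroxidase (Homo sapiens), with stated times of 10 min and 15 min; on this read-out lower numbers stand for stronger inhibition and higher numbers for weaker inhibition. Compound 1 `Nc1cc(Cc2ccn(-c3ccccn3)n2)c2nn[nH]c2n1` carries a pyridin-2-yl on the pyrazole nitrogen and gives 2000 nM in this assay. Compound 2 `Nc1cc(Cc2ccn(Cc3ccc4ccccc4c3)n2)c2nn[nH]c2n1` carries a naphthalen-2-ylmethyl there and gives 1100 nM. Compound 3 `Nc1cc(Cc2ccn(Cc3cccc(Cc4ccccc4)c3)n2)c2nn[nH]c2n1` carries a benzyl-substituted benzyl group and gives 1900 nM. On these numbers compound 3 has the second highest of the three values, yet its gap to compound 1 and its gap to compound 2 both fall inside the usual scatter, so the three compounds cannot be separated in this assay.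

Compound 4 `Nc1cc(Cc2ccn(Cc3cccc(C4CCNCC4)c3)n2)c2nn[nH]c2n1` has not yet been measured in this assay. It differs from compound 3 as follows: piperidin-4-yl in place of benzyl on an aromatic carbon. Going by the values given here, no measured pair tells how such a change acts here, so the expectation rests only on the narrow spread of the three measured values.

For compound 4 the estimated step from compound 3 is a 1.3-fold lower number from compound 3 to compound 4 (0.10 log units; within the scatter), which is expected to be none beyond the scatter. Compound 4 is therefore expected to give about 1500 nM in this assay, with a range from 500 nM to 5000 nM.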

Compound 4, half-maximal inhibitory concentration: 21000 nM
Compound 4: the middle estimate sits 14-fold (1.15 log units) below what was measured; the whole stated range lies below it.
By their numbers in this assay, from the lowest: compounds 2, 3 and 1 (each within the scatter of the next); then compound 4.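

In this assay, going by these compounds alone, piperidin-4-yl in place of benzyl on an aromatic carbon, meta to a large group, gives an 11-fold higher number from compound 3 to compound 4 (1.04 log units; beyond the scatter) and is the first step to lie beyond the scatter. Within the data shown here, this position is therefore not indifferent to what it carries, which the earlier compounds could not show, as no two of them differ in one place. The change swaps an aromatic ring of carbon only for a non-aromatic ring with a nitrogen, and it adds a hydrogen-bond donor and acceptor, so this single pair cannot separate the loss of the aromatic ring from the arrival of the nitrogen, and no measurement on hand accounts for the step.

Still open, on these data alone, is whether cyclohexyl at the same place, which has the non-aromatic ring without the nitrogen, or an aminomethyl group on the same ring, which has a nitrogen without that ring, would read close to compound 3 or close to compound 4. Also open, as far as these compounds go, is whether a carboxylic acid or a longer carbon chain at this place would be tolerated.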